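Swapping a Dichlorobenzyl Arm for a Piperidine Chain

A few compounds are considered here, and "the series" means these few. Any claim that something is new, unique, unknown or untested is made for them only; others in the source may bear on it.

Measured so far:
compound 1 `Nc1nc(O)c2c(n1)n(C1OC(CO)[C@@H](O)[C@H]1O)c(=O)n2Cc1ccc(Cl)c(Cl)c1`: 55%
compound 2 `CCCn1c(=O)n(C2OC(COP(=O)(O)O)[C@@H](O)[C@H]2O)c2nc(N)nc(O)c21`: 76%
compound 3 `CC1OC(n2c(=O)n(C)c3c(O)nc(N)nc32)[C@H](O)[C@@H]1O`: 0%

Of the compounds shown here, three have been measured in a functional assay on the whole organism (B cells) with Mus musculus as the target; a higher number here means a larger maximal response, a lower number a smaller maximal response. Compound 1 stands second of the three: compound 2 lies higher, beyond the scatter, and compound 3 lies far lower, also beyond the scatter. Compound 4 `Nc1nc(O)c2c(n1)n(C1OC(CO)[C@@H](O)[C@H]1O)c(=O)n2CCN1CCCCC1` has not yet been measured. It differs from compound 1 in one place: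
(piperidin-1-yl)methyl in place of 3,4-dichlorophenyl on a saturated chain carbon bound to an aromatic nitrogen
Within the data shown here, no measured pair shows a one-place change of this kind, so the size of the step is open. Without such a comparison, no step beyond the scatter in this assay is expected, in either direction, though the uncertainty is wide. For compound 4 the estimate is 50%, in the range 20% to 80%, which is an expected step of a number 5 percentage points lower from compound 1 to compound 4 (within the scatter).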

Compound 4, largest response reached (reported as maximal response), in percent of the reference or control that the assay uses: 0%
Beside the measured number, compound 4's estimate is 50 percentage points above it; measured number below the stated range.
By their numbers in this assay, from the lowest: compounds 3 and 4 (each within the scatter of the next); then compound 1; then compound 2.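

In this assay, exchanging 3,4-dichlorobenzyl for 2-(piperidin-1-yl)ethyl gives a step of a number 55 percentage points lower from compound 1 to compound 4 (beyond the scatter). This first single-place comparison shows that the group on this chain carbon can decide whether any response remains, so this position does not accept every six-membered ring on a short chain. No measurement shown here explains the step.

The change removes the aromatic ring and both chlorines and brings in a ring nitrogen, all at once, and the compounds shown do not separate these parts. Plain benzyl, 4-chlorobenzyl and 2-cyclohexylethyl remain open at this position.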